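Removing one methoxy group from a pyrazole chalcone

This account rests on a few compounds, and the source may have more. Where it says the series, first, only, none or still open, it means among the compounds named here.

Measured compounds:
- compound 1, `COc1ccc(-c2cc(/C=C/C(=O)c3ccc(N)cc3)[nH]n2)cc1`: 94%
- compound 2, `COc1cc(-c2cc(/C=C/C(=O)c3ccc(N)cc3)[nH]n2)cc(OC)c1OC`: 91%

Both compounds were tested in a functional assay on MCF7 cells (Homo sapiens) for cytotoxicity, read by sulforhodamine B assay, with a stated time of 48 h, tested at 0.1 uM; on this read-out lower numbers stand for a stronger effect and higher numbers for a weaker effect at the one concentration tested. In this assay compound 1 gives 94% and compound 2 gives 91%. These two numbers lie within the scatter of each other, so neither compound can be called more or less active than the other; compound 2 simply sits alongside compound 1 at a high read-out that means only a weak effect at the single concentration tested.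

Compound 3, `COc1ccc(-c2cc(/C=C/C(=O)c3ccc(N)cc3)[nH]n2)cc1OC`, has not yet been measured. Compared with compound 2 the change is small: hydrogen in place of methoxy on an aromatic carbon. For the measured compounds named here, no step between two measured compounds is known for this assay, and the two measured values show no difference beyond the scatter. The step of a number 1 percentage points higher from compound 2 to compound 3 (within the scatter) is therefore expected to be small, with no direction beyond the scatter. For compound 3 the estimated value in this assay is 92%, with a range from 82% to 100%.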

Compound 3, a percentage reported as activity, at one concentration (the size of the read-out at that concentration, not a potency): 89%
Beside the measured number, compound 3's estimate is 3 percentage points above it; low and high end bracket the measured number.
By their numbers in this assay, from the lowest: compounds 3, 2 and 1 (each within the scatter of the next).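

For the compounds shown here, compound 3 gives the first steps that can be read on this ring in this assay. Taking away the methoxy group that sits ortho to a methoxy group and meta to a large group gives a number 2 percentage points lower from compound 2 to compound 3 (within the scatter), and the reverse kind of exchange, methoxy in place of hydrogen at another aromatic carbon, gives a number 5 percentage points lower from compound 1 to compound 3 (within the scatter). Both steps lie within the scatter, so on this evidence an exchange between hydrogen and methoxy on this ring cannot be told apart from repeat-to-repeat variation, all three compounds remain at high numbers that stand for only a weak effect at the one concentration tested, and no measurement at hand offers an explanation for this result.

The compounds shown leave open whether a different group at this aromatic carbon, such as a hydroxy group, a fluorine atom or a longer chain like ethoxy, would give a step beyond the scatter. They also leave open whether the three compounds would separate at a higher concentration, since a single concentration gives the size of a read-out and not a potency.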